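A few compounds are considered here, and "the series" means these few. Any claim that something is new, unique, unknown or untested is made for them only; others in the source may bear on it.

Working notes on the series. The shared core of compound 1 `Cc1[nH]c2ccccc2c1C(C1=C(O)C(=O)c2ccccc2C1=O)c1ccc(Cl)cc1`, compound 2 `O=C1C(O)=C(C(c2ccc([N+](=O)[O-])cc2)c2c(-c3ccccc3)[nH]c3ccccc23)C(=O)c2ccccc21` and compound 3 `Cc1[nH]c2ccccc2c1C(C1=C(O)C(=O)c2ccccc2C1=O)c1ccc([N+](=O)[O-])cc1` is the same throughout. In a functional assay on ECa-109 cells (Homo sapiens) for cytotoxicity, read by MTT assay, with a stated time of 48 h (on this read-out higher numbers stand for weaker inhibition and lower numbers for stronger inhibition), compound 1 gives 14300 nM, compound 2 gives 5080 nM and compound 3 gives 6000 nM. Compound 3 thus holds the second highest number of the three: its nearest neighbour is compound 2, within the scatter, and its furthest is compound 1, beyond it. The two measured steps are a 2.4-fold lower number from compound 1 to compound 3 (0.38 log units; beyond the scatter) and a 1.2-fold higher number from compound 2 to compound 3 (0.07 log units; within the scatter).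

Compound 4 `O=C1C(O)=C(C(c2ccc([N+](=O)[O-])cc2)c2c[nH]c3ccc(Br)cc23)C(=O)c2ccccc21` differs from compound 3 at the indole: 5-bromo-1H-indol-3-yl in place of 2-methyl-1H-indol-3-yl on a saturated chain carbon bound to an aromatic carbon and a double-bonded ring carbon. Among the measured compounds shown here, of the measured steps only the one from compound 2 to compound 3 touches the indole, and a 1.2-fold higher number from compound 2 to compound 3 (0.07 log units; within the scatter) shows no move beyond the scatter. The exchange of 2-methyl-1H-indol-3-yl for 5-bromo-1H-indol-3-yl as such is not covered by any measured pair. Given that the one indole step a 1.2-fold higher number from compound 2 to compound 3 (0.07 log units; within the scatter) stayed within the scatter, a step of no more than the scatter is expected in this assay, in either direction, so that a 1.1-fold lower number from compound 3 to compound 4 (0.04 log units; within the scatter). Compound 4 is estimated at 5500 nM, with a range from 2000 nM to 15000 nM.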

Compound 4, half-maximal inhibitory concentration: 16900 nM
Estimate against measurement, compound 4: 3.1-fold (0.49 log units) below, outside the stated range (above it).
By their numbers in this assay, from the lowest: compounds 2 and 3 (each within the scatter of the next); then compounds 1 and 4 (each within the scatter of the next).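

At the saturated chain carbon, the indole now shows a move beyond the scatter in this assay: a 2.8-fold higher number from compound 3 to compound 4 (0.45 log units; beyond the scatter), a modest loss of inhibition, whereas a 1.2-fold higher number from compound 2 to compound 3 (0.07 log units; within the scatter) left the number within the scatter. This position is therefore not indifferent to the indole it carries, even though 2-methyl-1H-indol-3-yl and 5-bromo-1H-indol-3-yl have the same ring types and the same count of heavy atoms, and the exchange removes the methyl and adds the bromine in a single step, so the two edits cannot be separated here. Nothing at hand explains the shift, and no measurement bears on its cause.

The compounds shown leave open how plain 1H-indol-3-yl, carrying neither methyl nor bromine, would fall in this assay, and with it which of the two edits accounts for the step. They also leave open whether a methoxy group or an amine in place of the bromine would give a similar number, and whether the step would hold with chloro in place of nitro on the aromatic carbon.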